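From Bromo to Vinyl on a Shared Core

The source may hold more compounds than are shown below. What is called first, only, known or untested is meant among the compounds shown, and "the series" means these compounds.

Measured in an ADME assay on HEp-2 cells (Homo sapiens) for cytotoxicity; on this read-out higher numbers stand for lower toxicity in this test and lower numbers for higher toxicity in this test:
- Compound 1 `CC(C)CCn1c(Cn2c(=O)n(C(C)C)c3ccccc32)nc2cc(CN)ccc21`: 3920 nM
- Compound 2 `CC(C)CCn1c(Cn2c(=O)n(C(C)C)c3ccccc32)nc2cc(CO)ccc21`: 31600 nM
- Compound 3 `CC(C)CCn1c(Cn2c(=O)n(C(C)C)c3ccccc32)nc2cc(Br)ccc21`: 18100 nM

These three compounds differ only in one group on an aromatic carbon of the shared core. Compound 3 belongs to the upper pair. Its value cannot be separated from that of its nearest neighbour, a 1.7-fold lower number from compound 2 to compound 3 (0.24 log units; within the scatter), while it stands clear of the lowest value, a 4.6-fold higher number from compound 1 to compound 3 (0.66 log units; beyond the scatter).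

Compound 4 `C=Cc1ccc2c(c1)nc(Cn1c(=O)n(C(C)C)c3ccccc31)n2CCC(C)C` carries vinyl in place of bromo on an aromatic carbon. Going by the values given here, no measured step involves vinyl, so the guidance is indirect. Among the compounds with values here, the two clear steps, an 8.1-fold higher number from compound 1 to compound 2 (0.91 log units; beyond the scatter) and a 4.6-fold higher number from compound 1 to compound 3 (0.66 log units; beyond the scatter), both start from compound 1, the only compound with an amino group. Vinyl brings no amino group, and the one step without it stayed small: a 1.7-fold lower number from compound 2 to compound 3 (0.24 log units; within the scatter). No step beyond the scatter is therefore expected in this assay.

The expected step is a 1.1-fold lower number from compound 3 to compound 4 (0.03 log units; within the scatter). For compound 4 the estimated value is 17000 nM, with an expected range from 7500 nM to 38000 nM.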

Compound 4, half-maximal cytotoxic concentration: 6520 nM
Compound 4: middle estimate off by 2.6-fold (0.42 log units), on the high side, and the stated range ends above it.
By their numbers in this assay, from the lowest: compounds 1 and 4 (each within the scatter of the next); then compounds 3 and 2 (each within the scatter of the next).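

In this assay, this position proves sensitive to a swap between two groups that both lack hydrogen-bond donors and acceptors, since vinyl in place of bromo gives a clear change (a 2.8-fold lower number from compound 3 to compound 4 (0.44 log units; beyond the scatter)). Vinyl also stands clearly apart from hydroxymethyl (a 4.8-fold lower number from compound 2 to compound 4 (0.69 log units; beyond the scatter)) but cannot be separated from aminomethyl (a 1.7-fold higher number from compound 1 to compound 4 (0.22 log units; within the scatter)), so among these compounds a low number no longer belongs only to the compound with an amino group. Nothing available explains this shift. Still open, going by these compounds, is whether the double bond of vinyl matters, which ethyl at this place would help to show. Also open, on these data alone, is how a carboxylic acid or a longer chain would read here.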